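Compound 3 and rat microsomal stability

The source may report more compounds than this note shows. Statements on the series, on what has been measured and on what is new or still open speak of the compounds shown alone.

compound 1 `Cc1nc(N2CCN(C)CC2)c2nc(-c3cccc(Cl)c3)n(C3CCOCC3)c2n1`: 45%
compound 2 `COc1cccc(-c2nc3c(N4CCN(C)CC4)nc(C)nc3n2C2CCOCC2)c1`: 30%

In an ADME assay (liver) for metabolic stability, with Liver microsome (Rattus norvegicus) as the target, read by LC-MS, using microsomes, with a stated time of 30 min, tested at 4 uM (a higher number here means that more of the compound is left, a lower number that less of the compound is left), compound 2 stands lowest of the two at 30%, with compound 1 higher at 45%. Compound 3 `Cc1nc(N2CCN(C)CC2)c2nc(-c3ccccc3F)n(C3CCOCC3)c2n1` follows from compound 2 through (2-fluorophenyl in place of 3-methoxyphenyl on an aromatic carbon), 2-fluorophenyl in place of 3-methoxyphenyl on an aromatic carbon. Going by the values given here, one measured step bears on this, a number 15 percentage points lower from compound 1 to compound 2 (beyond the scatter), methoxy in place of chloro on an aromatic carbon. Among the compounds with values here, no measured compound carries 2-fluorophenyl, so this guide is only partial. Compound 3 also loses the methoxy, so a rise of similar size is expected, stated as a number 12 percentage points higher from compound 2 to compound 3 (beyond the scatter). For compound 3 the estimated value is 42%, with an expected range from 26% to 58%.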

Compound 3, percent of the compound remaining: 30%
The estimate for compound 3 lay 12 percentage points above the measured number; the range from low to high includes it.
By their numbers in this assay, from the lowest: compounds 2 and 3 (each within the scatter of the next); then compound 1.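

In this assay, the methoxy group proves not to be what separates compound 2 from compound 1: 2-fluorophenyl in place of 3-methoxyphenyl gives no change at the digits printed from compound 2 to compound 3 (within the scatter), and 2-fluorophenyl in place of 3-chlorophenyl gives a number 15 percentage points lower from compound 1 to compound 3 (beyond the scatter). At this aromatic carbon, then, compound 1 with its 3-chlorophenyl stands apart from the other two compounds, and a fluorine offers no gain over a methoxy. Nothing available explains this result. The compounds shown leave open whether the halogen itself or its place on the phenyl ring sets the number, which a 3-fluorophenyl or 2-chlorophenyl group would help to separate.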